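Moving the Bromine on the Sulfonamide Aryl Ring

The source may report more compounds than this note shows. Statements on the series, on what has been measured and on what is new or still open speak of the compounds shown alone.

In a functional assay on MCF7 cells (Homo sapiens) for antiproliferative activity, read by sulforhodamine B assay, with a stated time of 48 h (a lower number here means a stronger inhibitor, a higher number a weaker inhibitor), compound 1 `O=C1NCCN1c1ccc(S(=O)(=O)Nc2cccc(Br)c2)cc1` gives 100 nM, compound 2 `Cc1ccccc1NS(=O)(=O)c1ccc(N2CCNC2=O)cc1` gives 280 nM, and compound 3 `O=C1NCCN1c1ccc(S(=O)(=O)Nc2ccc(F)c(F)c2)cc1` gives 620 nM. Compound 3 thus stands highest of the three: the step of a 2.2-fold higher number from compound 2 to compound 3 (0.35 log units; beyond the scatter) and the step of a 6.2-fold higher number from compound 1 to compound 3 (0.79 log units; beyond the scatter) both lead to weaker inhibition in this assay. Compound 4 `O=C1NCCN1c1ccc(S(=O)(=O)Nc2ccc(Br)cc2)cc1` carries 4-bromophenyl in place of 3,4-difluorophenyl on a sulfonamide nitrogen. The step bearing most on this change is a 6.2-fold higher number from compound 1 to compound 3 (0.79 log units; beyond the scatter), which ran toward a higher number when 3-bromophenyl gave way to 3,4-difluorophenyl; the step of a 2.2-fold higher number from compound 2 to compound 3 (0.35 log units; beyond the scatter) points the same way. Returning to a bromophenyl is therefore expected to lower the number, though compound 1 is the only bromophenyl measured and its bromine is the 3-bromophenyl, not the 4-bromophenyl. Compound 4 is accordingly estimated at 160 nM, between 60 nM and 450 nM, a step of a 3.9-fold lower number from compound 3 to compound 4 (0.59 log units; beyond the scatter).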

Compound 4, half-maximal inhibitory concentration: 240 nM
Estimate against measurement, compound 4: 1.5-fold (0.18 log units) below; the range from low to high includes it.
By their numbers in this assay, from the lowest: compound 1; then compounds 4 and 2 (each within the scatter of the next); then compound 3.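

Bromine alone does not set the number in this assay, since 4-bromophenyl in place of 3-bromophenyl costs activity beyond the scatter (a 2.4-fold higher number from compound 1 to compound 4 (0.38 log units; beyond the scatter)). The 4-bromophenyl group still improves on 3,4-difluorophenyl (a 2.6-fold lower number from compound 3 to compound 4 (0.41 log units; beyond the scatter)), yet it cannot be told apart from 2-methylphenyl, the two lying within the scatter (a 1.2-fold lower number from compound 2 to compound 4 (0.07 log units; within the scatter)). Nothing at hand explains these differences. Still open, from the compounds shown here alone, is whether the preference for 3-bromophenyl extends to other single atoms or groups there. An amine or a carboxylic acid in place of the bromine remains untested among the compounds shown.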